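Pyridin-2-yl for naphthalen-1-yl on the piperazine of compound 2

The compounds below may be only part of what the source reports. "The series", "measured", "known", "first", "only" and "open" are said of these compounds alone.

Measured so far:
compound 1 `O=C1c2ccccc2S(=O)(=O)N1CCCCCCN1CCN(c2cccc(Cl)c2Cl)CC1` gives 487 nM
compound 2 `O=C1c2ccccc2S(=O)(=O)N1CCCCCN1CCN(c2cccc3ccccc23)CC1` gives 36 nM
compound 3 `COc1ccccc1N1CCN(Cc2ccc(CN3C(=O)c4ccccc4S3(=O)=O)cc2)CC1` gives 97 nM

In an assay on HEK293 cells for displacement of a labelled ligand from 5-hydroxytryptamine receptor 7 (Homo sapiens) (a lower number here means a stronger inhibitor, a higher number a weaker inhibitor), compound 2 stands lowest of the three numbers and is the strongest binder of the set; compound 3 comes nearest and compound 1 furthest, both beyond the scatter. Compound 4 `O=C1c2ccccc2S(=O)(=O)N1CCCCCN1CCN(c2ccccn2)CC1` is not yet measured. It differs from compound 2 in one place: pyridin-2-yl in place of naphthalen-1-yl on an amine nitrogen in a ring. Going by the values given here, no step between measured compounds is recorded, so there is nothing directly comparable to lean on; the three aryl groups on the amine nitrogen in a ring span a wide range, with the naphthalen-1-yl of compound 2 giving the lowest number. Taking the leaving of the larger group for a smaller heteroaryl, a step weaker than compound 2 and beyond the scatter is expected, of the size a 6.9-fold higher number from compound 2 to compound 4 (0.84 log units; beyond the scatter). Compound 4 is therefore estimated at 250 nM, with a range from 80 nM to 800 nM.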

Compound 4, inhibition constant: 179 nM
Compound 4: the middle estimate sits 1.4-fold (0.15 log units) above what was measured; the measured number falls inside the stated range.
By their numbers in this assay, from the lowest: compound 2; then compounds 3 and 4 (each within the scatter of the next); then compound 1.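

In this assay, going by these compounds alone, the change at this position on an amine nitrogen in a ring gives a 5.0-fold higher number from compound 2 to compound 4 (0.70 log units; beyond the scatter) and is the first step with only one place altered, showing that this group alone moves the number beyond the scatter. The step is modest, and compound 4 at 179 nM shows that one six-membered aromatic ring with 1 hetero atom can stand in this place without the second ring of naphthalen-1-yl. The step cannot separate the loss of that second ring from the entry of the ring nitrogen, and no supporting measurement bears on its cause.

Plain phenyl at this position would help to separate those two changes. From the compounds shown here alone, it also remains open whether the step carries over to the longer chain of compound 1.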